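This account rests on a few compounds, and the source may have more. Where it says the series, first, only, none or still open, it means among the compounds named here.

Of the compounds shown here, two that share a common core have so far been measured in a functional assay on HCT-116 cells (Homo sapiens) for antiproliferative activity, read by MTT assay, with a stated time of 72 h; a lower number here means a stronger inhibitor, a higher number a weaker inhibitor. Compound 1 `Cc1ccc(NC(=O)CCc2cccc3c2B(O)OC3)cc1` gives 4500 nM in this assay. Compound 2 `O=C(CCc1cccc2c1B(O)OC2)Nc1cccc(-c2ccc(F)cc2)c1` gives 550 nM in this assay, the lower of the two numbers, and the gap between the two values lies beyond the usual scatter of repeated measurements. Compound 3 `N#Cc1cccc(-c2cccc(NC(=O)CCc3cccc4c3B(O)OC4)c2)c1` has not yet been measured. It differs from compound 2 in a single place: 3-cyanophenyl in place of 4-fluorophenyl on an aromatic carbon. Going by the values given here, no measured pair in this set shows what a swap of this kind does in this assay, so there is no step to lean on. With an aromatic ring kept in place and only the group on it changed, no large swing is expected in this assay. The expected step is a 1.3-fold higher number from compound 2 to compound 3 (0.10 log units; within the scatter), a change within or close to the scatter. Compound 3 is therefore estimated at 700 nM, with a range from 250 nM to 2000 nM.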

Compound 3, half-maximal inhibitory concentration: 140 nM
Compound 3: middle estimate off by 5.0-fold (0.70 log units), on the high side; measured number outside the range, below it.
By their numbers in this assay, from the lowest: compound 3; then compound 2; then compound 1.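

In this assay, 3-cyanophenyl in place of 4-fluorophenyl gives a 3.9-fold lower number from compound 2 to compound 3 (0.59 log units; beyond the scatter). Going by these compounds alone, this is the first single-place comparison in the set, and it shows that the activity responds to what the outer aromatic ring carries, even when the ring itself stays in place. Nothing available explains why the number falls with this swap.

The swap replaces fluorine with a nitrile and also changes where the group sits on the ring, so these compounds cannot separate the effect of the group from the effect of its location. As far as these compounds go, it also remains open how this assay would respond to other groups on that ring, such as an amine or a carboxylic acid.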